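Adding a sulfonyl group to the amine of compound 1

The source may report more compounds than this note shows. Statements on the series, on what has been measured and on what is new or still open speak of the compounds shown alone.

Measured compounds:
compound 1 `CCCCc1ccc(CNCc2ccccc2)c(=O)n1Cc1ccc(-c2ccccc2-c2nn[nH]n2)cc1` gives 1 nM
compound 2 `CCCCc1ccc(CNS(=O)(=O)c2ccccc2)c(=O)n1Cc1ccc(-c2ccccc2-c2nn[nH]n2)cc1` gives 7 nM

Both compounds were tested in a functional assay (aorta) for antagonist activity, with Oryctolagus cuniculus as the target; a higher number here means a weaker inhibitor, a lower number a stronger inhibitor. Compound 1 stands at the lowest of the two numbers; its nearest neighbour is compound 2, reached by a 7.0-fold higher number from compound 1 to compound 2 (0.85 log units; beyond the scatter), a modest step. Compound 3 `CCCCc1ccc(CN(Cc2ccccc2)S(=O)(=O)c2ccc(C)cc2)c(=O)n1Cc1ccc(-c2ccccc2-c2nn[nH]n2)cc1` keeps the benzyl of compound 1 and carries in addition ((4-methylphenyl)sulfonyl in place of hydrogen on an amine nitrogen). Within the data shown here, the only measured step that bears on this change is the one from compound 1 to compound 2, in which a sulfonyl group entered on that same nitrogen at the cost of the benzyl; there the number rose beyond the scatter. With a sulfonyl entering while the benzyl stays, a rise of comparable size is expected. Compound 3 is therefore estimated at 10 nM, with a range from 2 nM to 60 nM, which corresponds to an expected 10-fold higher number from compound 1 to compound 3 (1.00 log units; beyond the scatter).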

Compound 3, half-maximal inhibitory concentration: 60 nM
Beside the measured number, compound 3's estimate is 6.0-fold (0.78 log units) below it, and the stated range covers the measured number.
By their numbers in this assay, from the lowest: compound 1; then compound 2; then compound 3.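

Replacing the hydrogen on the amine nitrogen of compound 1 while keeping the benzyl gave a 60-fold higher number from compound 1 to compound 3 (1.78 log units; beyond the scatter) in this assay and counted as a large step, whereas the earlier exchange of benzyl for phenylsulfonyl, a 7.0-fold higher number from compound 1 to compound 2 (0.85 log units; beyond the scatter), was modest. The hydrogen on this nitrogen is therefore not a neutral point of attachment, and a (4-methylphenyl)sulfonyl group added there, with both saturated chain carbons retained, carries a clear cost in this series. No evidence accompanies these compounds that would explain the result.

The compounds shown leave open whether the rise follows from losing the hydrogen or from the group that enters. A methyl or an acetyl on the same nitrogen, or a methanesulfonyl group in place of the (4-methylphenyl)sulfonyl, would help separate those two readings.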